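Compound 2 to its 4-aminophenyl analogue

A few compounds are considered here, and "the series" means these few. Any claim that something is new, unique, unknown or untested is made for them only; others in the source may bear on it.

- compound 1 `COc1ccc(Oc2ccccc2NC(C)=C2C(=O)CC(c3ccccc3)CC2=O)cc1` gives 120 nM
- compound 2 `COc1ccc(Oc2ccccc2NC(C)=C2C(=O)CC(c3ccccc3)CC2=O)cc1OC` gives 160 nM
- compound 3 `CC(Nc1ccccc1Oc1cccc(N)c1)=C1C(=O)CC(c2ccccc2)CC1=O` gives 42 nM

All three values come from a functional assay on CCRF-CEM cells (Homo sapiens) for antiproliferative activity, read by cell counting, with a stated time of 96 h; a lower number here means a stronger inhibitor, a higher number a weaker inhibitor. Compound 2 stands at the high end of these numbers, level with compound 1 within the scatter: a 1.3-fold higher number from compound 1 to compound 2 (0.12 log units; within the scatter). Compound 4 `CC(Nc1ccccc1Oc1ccc(N)cc1)=C1C(=O)CC(c2ccccc2)CC1=O` has 4-aminophenyl in place of 3,4-dimethoxyphenyl on an oxygen on an aromatic ring. The closest evidence is the entry of 3-aminophenyl at that place, a modest step: a 3.8-fold lower number from compound 2 to compound 3 (0.58 log units; beyond the scatter). The same group gives a 2.9-fold lower number from compound 1 to compound 3 (0.46 log units; beyond the scatter). For the measured compounds named here, no 4-aminophenyl compound has been measured, so this transfer is uncertain. A modest step to a lower number in this assay is expected, estimated as a 3.2-fold lower number from compound 2 to compound 4 (0.51 log units; beyond the scatter). Compound 4 is estimated at 50 nM with an expected range from 18 nM to 130 nM.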

Compound 4, half-maximal inhibitory concentration: 37 nM
The estimate for compound 4 lay 1.4-fold (0.13 log units) above the measured number, within the range that was stated.
By their numbers in this assay, from the lowest: compounds 4 and 3 (each within the scatter of the next); then compounds 1 and 2 (each within the scatter of the next).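

In this assay, 4-aminophenyl and 3-aminophenyl cannot be told apart on this oxygen (a 1.1-fold lower number from compound 3 to compound 4 (0.06 log units; within the scatter)), so the two amino placements shown give the same reading. The gain over the methoxy-bearing rings holds for 4-aminophenyl too, with a 4.3-fold lower number from compound 2 to compound 4 (0.64 log units; beyond the scatter) and a 3.2-fold lower number from compound 1 to compound 4 (0.51 log units; beyond the scatter), the latter being amino in place of methoxy on an aromatic carbon. No measurement here accounts for this difference. The compounds shown leave open whether the gain needs the amino group or follows from losing methoxy. An unsubstituted phenyl, hydroxyl or dimethylamino group at this ring would separate the two.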